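This account rests on a few compounds, and the source may have more. Where it says the series, first, only, none or still open, it means among the compounds named here.

Compound 1 `Cc1nnc(SCC(=O)N/N=c2/scc(-c3ccc([N+](=O)[O-])cc3)n2-c2ccccc2)s1`: 177 ug/mL
Compound 2 `Cc1nnc(SCC(=O)N/N=c2/scc(-c3ccc(Cl)cc3)n2-c2ccccc2)s1`: 253 ug/mL
Compound 3 `Cc1nnc(SCC(=O)N/N=c2/scc(-c3ccc(C#N)cc3)n2-c2ccccc2)s1`: < 3.9 ug/mL, a limit of the assay

In an ADME assay on NIH3T3 cells (Mus musculus) for cytotoxicity, read by MTT assay, with a stated time of 24 h (a lower number here means a stronger inhibitor, a higher number a weaker inhibitor), compound 1 gives 177 ug/mL and compound 2 gives 253 ug/mL. Compound 3 gives only (the limit of < 3.9 ug/mL in this assay, at which 1 of the 3 values shown sits), not a number. Compound 2 holds the higher of the two numbers, with compound 1 within the scatter of it. Compound 4 `Cn1nnnc1SCC(=O)N/N=c1/scc(-c2ccc(Cl)cc2)n1-c1ccccc1` differs from compound 2 by 1-methyl-1H-tetrazol-5-yl in place of 5-methyl-1,3,4-thiadiazol-2-yl on a sulfur. The measured steps all change the group on the aromatic carbon: a 1.4-fold higher number from compound 1 to compound 2 (0.16 log units; within the scatter), an at least 45-fold lower number from compound 1 to compound 3 (1.65 log units; beyond the scatter) and an at least 64-fold lower number from compound 2 to compound 3 (1.81 log units; beyond the scatter). Going by the values given here, none touches the ring on the sulfur, so no measured step bears directly on this change, and no shift beyond the scatter is expected in this assay. Compound 4 is therefore estimated at 230 ug/mL, between 80 ug/mL and 500 ug/mL. That estimate means an expected 1.1-fold lower number from compound 2 to compound 4 (0.04 log units; within the scatter).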

Compound 4, half-maximal inhibitory concentration: 40 ug/mL
For compound 4 the middle estimate is 5.8-fold (0.76 log units) above the measured one; the measured number lies below the stated range.
By their numbers in this assay, from the lowest: compound 4; then compounds 1 and 2 (each within the scatter of the next). At a limit, below all of these: compound 3.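

The ring on the sulfur matters in this assay: 1-methyl-1H-tetrazol-5-yl in place of 5-methyl-1,3,4-thiadiazol-2-yl gives a 6.3-fold lower number from compound 2 to compound 4 (0.80 log units; beyond the scatter). Going by these compounds alone, earlier steps changed only the group on the aromatic carbon, so this is the first sign that the ring on the sulfur also moves the number. Nothing at hand explains this shift.

From the compounds shown here alone, whether the same ring change acts alike with nitro or cyano on the aromatic carbon stays open. So does the effect of an amine or a carboxylic acid in place of the ring on the sulfur.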